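The source may hold more compounds than are shown below. What is called first, only, known or untested is meant among the compounds shown, and "the series" means these compounds.

Measured so far in an ADME assay on HEK-293T cells (Homo sapiens) for cytotoxicity, read by CCK-8 assay, with a stated time of 48 h; on this read-out lower numbers stand for higher toxicity in this test and higher numbers for lower toxicity in this test:
compound 1 `Cn1cc([S+]([O-])CC(=O)Nc2ccc(Cl)cc2)c2ccccc21` gives > 100000 nM, a limit of the assay rather than a number.
compound 2 `Cn1cc([S+]([O-])CC(=O)Nc2cccc(Cl)c2)c2ccccc21` gives > 100000 nM, also a limit rather than a number.
compound 3 `Cn1cc(SCC(=O)Nc2cccc(Cl)c2)c2ccccc21` gives > 100000 nM, also a limit rather than a number.

Compound 4 `Cn1cc(SCC(=O)Nc2ccc(Cl)cc2)c2ccccc21` is not yet measured in this assay. It differs from compound 3 by 4-chlorophenyl in place of 3-chlorophenyl on an amide-type nitrogen. The same change separates compound 2 from compound 1, (4-chlorophenyl in place of 3-chlorophenyl on an amide-type nitrogen), at a place described in the same words, so the two changes are the same. The step that the two limits leave unreadable from compound 2 to compound 1 cannot be read because of the limit of > 100000 nM in this assay, at which 3 of the 3 values shown sit. How the core of compound 3 differs from the core of compound 2 is not broken down here. Going by the values given here, with every value so far sitting at the limit, nothing indicates that the change moves the read-out, and compound 3 itself gives only a limit. The step that the limit leaves unreadable from compound 3 to compound 4 is therefore expected to be unreadable in the same way. Compound 4 is expected to give 150000 nM in this assay, most likely again as a limit rather than a number.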

Compound 4, half-maximal cytotoxic concentration: > 100000 nM
Compound 4: a limit, no number; the forecaster's own chance of this, stated with the estimate: 85%; the middle value does not contradict the limit.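

In this assay compound 4 gives > 100000 nM as a limit of the assay and not a number. No step can be read between compound 3 and compound 4 because both sit at the same limit: the limit of > 100000 nM in this assay, at which 4 of the 4 values shown sit. Still open, on these data alone, is whether 4-chlorophenyl in place of 3-chlorophenyl moves the read-out at all, and what half-maximal cytotoxic concentration any of the four compounds actually has.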